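The source may hold more compounds than are shown below. What is called first, only, known or untested is meant among the compounds shown, and "the series" means these compounds.

Two compounds define the starting point. Compound 1 `CC(C)CS(=O)(=O)N1C[C@@H]2[C@H](C1)[C@@]2(CNC(=O)c1ccc(Cl)cc1Cl)CC1CC1` and compound 2 `O=C(NC[C@]1(CC2CC2)[C@@H]2CN(S(=O)(=O)c3cccnc3)C[C@@H]21)c1ccc(Cl)cc1Cl` share one core and differ only in the group on the sulfonyl sulfur. In an assay on isolated protein for inhibition of sodium- and chloride-dependent glycine transporter 1 (Homo sapiens) (a lower number here means a stronger inhibitor, a higher number a weaker inhibitor), compound 1 gives 2900 nM, and compound 2 gives 890 nM. Among the compounds with values here, the single step between them, a 3.3-fold lower number from compound 1 to compound 2 (0.51 log units; beyond the scatter), is the only measured change available, and it leaves compound 2 with the lower of the two numbers in this assay.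

Compound 3 `Cn1cnc(S(=O)(=O)N2C[C@@H]3[C@H](C2)[C@@]3(CNC(=O)c2ccc(Cl)cc2Cl)CC2CC2)c1` is not yet measured. It differs from compound 2 in one place: 1-methyl-1H-imidazol-4-yl in place of pyridin-3-yl on a sulfonyl sulfur. Within the data shown here, no measured step covers an exchange of one aromatic ring for another on this sulfur; the step from compound 1 to compound 2 replaced an alkyl chain with an aromatic ring and was modest in size. Compound 3 keeps an aromatic ring on the sulfonyl sulfur. Because that step, a 3.3-fold lower number from compound 1 to compound 2 (0.51 log units; beyond the scatter), already brought compound 2 to its current value, the expected step of a 1.0-fold higher number from compound 2 to compound 3 (0.00 log units; within the scatter) is taken to be no larger than the usual scatter in this assay. Compound 3 is therefore estimated at 900 nM, with a range from 300 nM to 3000 nM.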

Compound 3, half-maximal inhibitory concentration: 4 nM
Estimate against measurement, compound 3: 230-fold (2.35 log units) above, outside the stated range (below it).
By their numbers in this assay, from the lowest: compound 3; then compound 2; then compound 1.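

In this assay, the group on the sulfonyl sulfur proves able to move the number much further than the first pair showed: exchanging one aromatic ring for another gives a 220-fold lower number from compound 2 to compound 3 (2.35 log units; beyond the scatter), a far larger step than a 3.3-fold lower number from compound 1 to compound 2 (0.51 log units; beyond the scatter) seen on replacing isobutyl with pyridin-3-yl. Measured against the isobutyl group, 1-methyl-1H-imidazol-4-yl gives a 730-fold lower number from compound 1 to compound 3 (2.86 log units; beyond the scatter), so having an aromatic ring on this sulfur does not by itself set the number, and the identity of the ring matters greatly: the two rings match in heavy atom count but differ in ring size, hetero atoms and hydrogen-bond acceptors. Nothing available accounts for the size of this step.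

Still open is whether the large step belongs to the five-membered ring, to its second nitrogen or to the methyl group of 1-methyl-1H-imidazol-4-yl, since the compounds shown do not separate these features. A 1H-imidazol-4-yl group without the methyl, a 1-ethyl-1H-imidazol-4-yl group or a 1-methyl-1H-pyrazol-4-yl group on the same sulfur would begin to pull them apart.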